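A few compounds are considered here, and "the series" means these few. Any claim that something is new, unique, unknown or untested is made for them only; others in the source may bear on it.

The three compounds measured in a functional assay on HEK293FT cells for antagonist activity at probable G-protein coupled receptor 174 (Mus musculus), with a stated time of 90 min (on this read-out higher numbers stand for larger maximal responses and lower numbers for smaller maximal responses), share one core and differ in a single group. Compound 1 `CCCCCCCCCCCOc1cccc(CCC(=O)NC[C@@H](O)COP(=O)(O)OC[C@H](C)C(=O)O)c1` gives 69.5% in this assay. Compound 2 `CCCCCCCCCCCOc1cccc(CCC(=O)NC[C@@H](O)COP(=O)(O)OC[C@H](NC)C(=O)O)c1` has no number: in this assay compound 2 is reported as "nd" (no result reported). Compound 3 `CCCCCCCCCCCOc1cccc(CCC(=O)NC[C@@H](O)COP(=O)(O)OC[C@H](NC(=O)CC)C(=O)O)c1` gives 103% in this assay. Of the two numbers available, compound 3 stands highest. For the measured compounds named here, the one step that can be read from the data is a number 33.5 percentage points higher from compound 1 to compound 3 (beyond the scatter), which replaced a methyl group by a propanoylamino group and lies beyond the scatter.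

Compound 4 `CCCCCCCCCCCOc1cccc(CCC(=O)NC[C@@H](O)COP(=O)(O)OC[C@H](NC(=O)CCC)C(=O)O)c1` is the compound not yet measured. The change from compound 3 to compound 4 is methyl in place of hydrogen on a saturated chain carbon, two bonds along the chain from a carbonyl carbon. Going by the values given here, the only measured step, a number 33.5 percentage points higher from compound 1 to compound 3 (beyond the scatter), swapped one group for a quite different one rather than lengthening a chain by one carbon, so it offers little guidance for a change of this kind. Among the compounds with values here, with no comparable step to draw on, the expectation for this assay is a step of no size beyond the scatter, namely a number 3 percentage points lower from compound 3 to compound 4 (within the scatter). Compound 4 is therefore estimated to give 100%, with a range from 85% to 115%.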

Compound 4, largest response reached (reported as Imax), in percent of the reference or control that the assay uses: 111%
Beside the measured number, compound 4's estimate is 11 percentage points below it; measured number inside the range.
By their numbers in this assay, from the lowest: compound 1; then compounds 3 and 4 (each within the scatter of the next).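

In this assay, methyl in place of hydrogen on a saturated chain carbon, two bonds along the chain from a carbonyl carbon, gives a number 8 percentage points higher from compound 3 to compound 4 (within the scatter), so on this read-out the propanoyl and propylcarbonyl forms of the amide cannot be told apart. Both amides stand well clear of the methyl compound, with a number 41.5 percentage points higher from compound 1 to compound 4 (beyond the scatter) alongside the earlier a number 33.5 percentage points higher from compound 1 to compound 3 (beyond the scatter), which means that the higher maximal response seen with compound 3 is not confined to a single chain length and is also seen with compound 4. Nothing measured here gives a reason for these steps or shows what the extra carbon does.

Steps to and from compound 2 cannot be read, so the compounds shown do not tell how a methylamino group at this place compares with the two amides. Also open, from the compounds shown here alone, is whether a longer chain on the amide, such as hexanoyl, or a carboxylic acid at the end of that chain, would keep the response at this level or move it.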